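The source may report more compounds than this note shows. Statements on the series, on what has been measured and on what is new or still open speak of the compounds shown alone.

Measured so far in an ADME assay on BJ cells (Homo sapiens) for cytotoxicity, read by CellTiter-Glo and resazurin assay, with a stated time of 72 h; on this read-out lower numbers stand for an effect already at smaller amounts and higher numbers for an effect only at larger amounts of compound:

compound 1 `CC(C)N(Cc1cccc(OCCCCCC(=O)O)c1)C(=O)c1ccc(-c2ccco2)cc1` – > 26000 nM

compound 2 `CC(C)N(Cc1cccc(OCCCCCC(=O)O)c1)C(=O)c1ccc(-c2cccc(OC(F)(F)F)c2)cc1` – > 26000 nM

In this assay compound 1 gives > 26000 nM, which is a limit of the assay and not a number. Compound 2 likewise gives > 26000 nM in this assay, again a limit. For the measured compounds named here, the only measured step, a step that the two limits leave unreadable from compound 1 to compound 2, therefore cannot be sized, because of the limit of > 26000 nM in this assay, at which 2 of the 2 values shown sit.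

Compound 3 `CCOC(=O)CCCCCOc1cccc(CN(C(=O)c2ccc(-c3ccco3)cc2)C(C)C)c1` differs from compound 1 in a single place: ethyl in place of hydrogen on an oxygen next to a carbonyl group. Going by the values given here, no measured pair bears on this change, since the one step that was measured is unreadable from two limits, and nothing beyond the two limits is known about compound 1. Given that compound 1 shows > 26000 nM in this assay, compound 3 is expected to sit in the same region, with the step of a number no higher from compound 1 to compound 3 (the limit leaves the size open) expected to stay within the scatter, and most likely again to be reported only as a limit. The estimate for compound 3 in this assay is 26000 nM, within a range from 8000 nM to 80000 nM.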

Compound 3, half-maximal effective concentration: > 26000 nM
Compound 3 ended at the assay's limit (the forecaster's own chance of this, stated with the estimate: 70%); the middle value sits exactly at the limit.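

No step can be read from compound 1 to compound 3 in this assay, since both values are limits of the assay and not numbers: the limit of > 26000 nM in this assay, at which 3 of the 3 values shown sit. The compounds shown leave open at what amount any of the three would reach a half-maximal effect, and whether ethyl in place of hydrogen on an oxygen next to a carbonyl group shifts that amount at all.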